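Swapping cyclopropylsulfonyl for cyano on compound 3

The source may report more compounds than this note shows. Statements on the series, on what has been measured and on what is new or still open speak of the compounds shown alone.

Of the compounds shown here, three with a shared core have been tested in an ADME assay on microsomes from liver (Rattus norvegicus) for metabolic stability, read by LC-MS, using NADPH, with a stated time of 30 min, tested at 0.1 uM, in the presence of a further agent that is not named here (on this read-out lower numbers stand for a less stable compound and higher numbers for a more stable compound), and none of them yet gives an exact number. Compound 1 (`NC(=O)c1ccc(-c2cnc(N)c(-c3ccc(C(F)(F)F)cc3)n2)cc1`) shows > 90% as a limit of the assay and not a number. Compound 2 (`Nc1ncc(-c2ccc(C(=O)N3CCC(O)C3)cc2)nc1-c1ccc(C(F)(F)F)cc1`) shows > 90% as a limit too. Compound 3 (`Nc1ccc(-c2nc(-c3ccc(S(=O)(=O)C4CC4)cc3)cnc2N)cn1`) shows > 90% as a limit as well, so its true value stays unread. The picture so far is the limit of > 90% in this assay, at which 3 of the 3 values shown sit, and no more.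

Compound 4 (`N#Cc1ccc(-c2cnc(N)c(-c3ccc(N)nc3)n2)cc1`) has not been measured yet. It differs from compound 3 by cyano in place of cyclopropylsulfonyl on an aromatic carbon, para to a large group (cyano in place of cyclopropylsulfonyl on an aromatic carbon). Within the data shown here, the one measured step that can be consulted also replaces a single group, but it is a step that the two limits leave unreadable from compound 1 to compound 2 and offers no size to carry over. Among the measured compounds shown here, no measured step points to a shift beyond the scatter in this assay and none is expected. That expectation starts from compound 3 with its limit of > 90% as the only anchor. The estimated step is small (a step that the limit leaves unreadable from compound 3 to compound 4). Compound 4 is expected at 92% (estimated range 78% to 100%).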

Compound 4, percent of the compound remaining: > 90%
Compound 4: a limit, no number (the forecaster's own chance of this, stated with the estimate: 60%); the middle value does not contradict the limit.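

No step can be read between compound 3 and compound 4, since both values are limits of the assay and not numbers: the limit of > 90% in this assay, at which 4 of the 4 values shown sit.

The compounds shown leave open how stable each one truly is in this assay, and whether cyano in place of cyclopropylsulfonyl changes the percent remaining at all.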